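The compounds below may be only part of what the source reports. "The series", "measured", "known", "first", "only" and "open" are said of these compounds alone.

Measured in a functional assay on HCT-116 cells (Homo sapiens) for cytotoxicity, read by scintillation counting and thymidine incorporation, with a stated time of 72 h; a higher number here means a weaker inhibitor, a lower number a stronger inhibitor:

- Compound 1 `C#CC=C(c1cc(OC)cc(OC)c1)c1ccc(OC)c(OC)c1`: > 10000 nM, a limit of the assay.
- Compound 2 `COc1cc(OC)cc(C(=CC#N)c2ccc(OC)c(OC)c2)c1`: 18 nM.
- Compound 3 `CCOc1cc(C(=CC#N)c2ccc(OC)c(-n3cccc3)c2)ccc1OC`: 49 nM.

Of the two actual numbers, compound 3 holds the higher one, and its gap to compound 2 lies beyond the scatter. Compound 4 `CCOc1cc(C(=CC#N)c2ccc(OC)c(F)c2)ccc1OC` differs from compound 3 as follows: fluoro in place of 1H-pyrrol-1-yl on an aromatic carbon. Within the data shown here, the only measured step, an at least 550-fold lower number from compound 1 to compound 2 (2.74 log units; beyond the scatter), is a large one, but it concerns cyano in place of ethynyl, which is a different exchange at a different place. It therefore gives no size or direction for this swap in this assay, and the anchor stays compound 3 at 49 nM. The expected outcome is a 1.0-fold higher number from compound 3 to compound 4 (0.01 log units; within the scatter), with no shift beyond the scatter firmly predicted. For compound 4 the estimate is 50 nM, with an expected range of 10 nM to 250 nM.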

Compound 4, half-maximal inhibitory concentration: 130 nM
Compound 4: the middle estimate sits 2.6-fold (0.41 log units) below what was measured, within the range that was stated.
By their numbers in this assay, from the lowest: compound 2; then compound 3; then compound 4. At a limit, above all of these: compound 1.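

In this assay, the aromatic carbon carrying 1H-pyrrol-1-yl in compound 3 proves sensitive to its substituent, with fluoro giving the weaker inhibitor (a 2.7-fold higher number from compound 3 to compound 4 (0.42 log units; beyond the scatter)). Among these compounds, the earlier step concerned only the chain, so this is the first reading at this position, and the five-membered aromatic ring holds up better here than the single fluorine atom. Nothing measured here bears on why the number rises. As far as these compounds go, whether a chloro group, an amine or a phenyl ring on this carbon would lower the number further or raise it remains open.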